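The compounds below may be only part of what the source reports. "The series", "measured", "known", "first", "only" and "open" are said of these compounds alone.

In a functional assay on HCT-8 cells (Homo sapiens) for cytotoxicity (a higher number here means that more compound is needed for the effect, a lower number that less compound is needed), compound 1 `CCOc1cc(-c2ccccc2)nc2ccccc12` gives > 10 ug/mL, which is a limit of the assay and not a number. Compound 3 `Oc1ccc2c(O)cc(-c3ccccc3)nc2c1` gives > 10 ug/mL, again only a limit. Among the compounds with values here, compound 2 `Oc1ccc2nc(-c3ccccc3)cc(O)c2c1` is the one compound here with a true number, 7.75 ug/mL. Compound 1 therefore stands at the limit of > 10 ug/mL in this assay, at which 2 of the 3 values shown sit. Compound 4 `CCCCOc1cc(-c2ccccc2)nc2ccccc12` keeps the core of compound 1 and turns ethoxy into butoxy, with ethyl in place of hydrogen on a saturated chain carbon, two bonds along the chain from an oxygen on an aromatic ring. Within the data shown here, no measured pair shows this kind of change, so no step beyond the usual scatter is expected in this assay, and the estimated step is a number no higher from compound 1 to compound 4 (the limit leaves the size open). For compound 4 the expected value is 10 ug/mL, with an estimated range from 5 ug/mL to 20 ug/mL.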

Compound 4, half-maximal effective concentration: > 10 ug/mL
Compound 4 gave a limit, no number; the forecaster's own chance of this, stated with the estimate: 70%; the middle value lies on the limit itself.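

Compound 4 gives > 10 ug/mL, a limit of the assay and not a number. Within the data shown here, compound 1 also gives only a limit, so no step between compound 1 and compound 4 can be read. The compounds shown leave open whether ethoxy and butoxy differ at all in this assay.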